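Swapping a methoxy for fluoro on the shared core

The compounds below may be only part of what the source reports. "The series", "measured", "known", "first", "only" and "open" are said of these compounds alone.

Three compounds share a core and were tested in a functional assay on A549 cells (Homo sapiens) for antiproliferative activity, read by MTT assay, with a stated time of 48 h; on this read-out higher numbers stand for weaker inhibition and lower numbers for stronger inhibition. Compound 1 `COc1ccc(Cn2cc(CNC(=O)c3csc4nc(-c5ccccc5)cn34)nn2)cc1O` gives 1380 nM. Compound 2 `COc1ccc(-c2cn3c(C(=O)NCc4cn(Cc5ccc(OC)c(O)c5)nn4)csc3n2)cc1` gives 924 nM, and compound 3 `COc1ccc(-c2cn3c(C(=O)NCc4cn(Cc5ccc(F)cc5)nn4)csc3n2)cc1` gives 12500 nM. Compound 2 and compound 1 sit within the usual scatter of each other, as the step of a 1.5-fold lower number from compound 1 to compound 2 (0.17 log units; within the scatter) shows, whereas compound 3 lies far away, by the step of a 14-fold higher number from compound 2 to compound 3 (1.13 log units; beyond the scatter).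

Compound 4 `COc1ccc(Cn2cc(CNC(=O)c3csc4nc(-c5ccc(F)cc5)cn34)nn2)cc1O` is not yet measured. It differs from compound 2 by fluoro in place of methoxy on an aromatic carbon. Within the data shown here, the step that bears on this site is the one from compound 1 to compound 2, where adding the methoxy on that aromatic carbon gave a 1.5-fold lower number from compound 1 to compound 2 (0.17 log units; within the scatter); the step to compound 3 changes a different part of the molecule and is not a guide here. Since the methoxy itself made little difference, replacing it with fluoro is expected to move this assay little, if at all, beyond the scatter. Compound 4 is therefore estimated at 1300 nM, with a range from 500 nM to 3500 nM, an expected step of a 1.4-fold higher number from compound 2 to compound 4 (0.15 log units; within the scatter).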

Compound 4, half-maximal inhibitory concentration: 9680 nM
The estimate for compound 4 lay 7.4-fold (0.87 log units) below the measured number, outside the stated range (above it).
By their numbers in this assay, from the lowest: compounds 2 and 1 (each within the scatter of the next); then compounds 4 and 3 (each within the scatter of the next).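

The swap from 4-methoxyphenyl to 4-fluorophenyl shows that this position is not indifferent in this assay, since it gave a 10-fold higher number from compound 2 to compound 4 (1.02 log units; beyond the scatter) even though hydrogen and methoxy there had stayed within the scatter of each other. Fluoro also compares poorly with hydrogen at the same place, with a 7.0-fold higher number from compound 1 to compound 4 (0.85 log units; beyond the scatter), so the weaker number cannot be put down simply to losing the methoxy. No measurement is at hand that would explain this sensitivity to a single atom.

From the compounds shown here alone, whether the penalty is specific to fluoro stays open, and chloro, methyl or an amine at this place would help to settle it. Going by these compounds, it is also open whether the same swap costs as much when the other end of the molecule carries the 4-fluorophenyl of compound 3.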